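A few compounds are considered here, and "the series" means these few. Any claim that something is new, unique, unknown or untested is made for them only; others in the source may bear on it.

The measured compounds are:

compound 1, `CCCCCCCCCCCC(=O)O[C@H]1C(=O)OCC1(C)C`, which in an assay on isolated protein for inhibition of fatty acid synthase (Mus musculus), read by spectrophotometry, using NADPH, with stated times of 30 min and 3 min, in the presence of a further agent that is not named here (a lower number here means a stronger inhibitor, a higher number a weaker inhibitor), gives 15200 nM;
compound 2, `CC1(C)COC(=O)[C@@H]1OC(=O)c1ccccc1`, which in this assay gives 23000 nM;
compound 3, `COc1ccc(C(=O)O[C@H]2C(=O)OCC2(C)C)cc1`, which in this assay gives 13700 nM.

Compound 3 has the lowest of the three numbers, but its gap to compound 1 and its gap to compound 2 both lie within the usual scatter, so no order among the three can be read from them. Going by the values given here, the one step that changes a single place, a 1.7-fold lower number from compound 2 to compound 3 (0.23 log units; within the scatter), is itself within the scatter and shows that putting a methoxy on the aromatic ring of the shared core did not move the number.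

Compound 4 is `CC1(C)COC(=O)[C@@H]1OC(=O)c1ccc(C#N)cc1`. It differs from compound 3 by cyano in place of methoxy on an aromatic carbon. Among the compounds with values here, no measured step exchanges a methoxy for a cyano, so the only bearing comes from the step from compound 2 to compound 3, which was small. The expectation is therefore a step of no more than the scatter, a 1.0-fold higher number from compound 3 to compound 4 (0.01 log units; within the scatter), in either direction. On that basis compound 4 is estimated at 14000 nM in this assay, with a range from 5000 nM to 40000 nM.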

Compound 4, half-maximal inhibitory concentration: 21500 nM
Beside the measured number, compound 4's estimate is 1.5-fold (0.19 log units) below it; the measured number falls inside the stated range.
By their numbers in this assay, from the lowest: compounds 3, 1, 4 and 2 (each within the scatter of the next).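

In this assay the two new steps, a 1.6-fold higher number from compound 3 to compound 4 (0.20 log units; within the scatter) and a 1.1-fold lower number from compound 2 to compound 4 (0.03 log units; within the scatter), both lie within the scatter. The earlier compounds shown here had tested only methoxy against hydrogen on this aromatic carbon, para to a large group; with cyano added, the hydrogen, methoxy and cyano compounds cannot be told apart by their numbers. The exchange of methoxy for cyano, and the addition of cyano in place of hydrogen, thus leave the reading unmoved at this position, and no measurement offered here speaks to what lies behind that.

On these data alone, whether an amine or a carboxylic acid in this place would carry the number beyond the scatter remains open. So does whether any change to the shared core itself, rather than to the ring attached to it, would do so.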